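A few compounds are considered here, and "the series" means these few. Any claim that something is new, unique, unknown or untested is made for them only; others in the source may bear on it.

Series notes. Compound 1 `COc1cc(-n2cc(-c3ccc(N)cc3)nn2)cc(OC)c1OC` has one core; compound 2 `COc1cc(-c2cn(-c3cc(OC)c(OC)c(OC)c3)nn2)cc(OC)c1OC` and compound 3 `COc1cc(OC)cc(-c2cn(-c3cc(OC)c(OC)c(OC)c3)nn2)c1` share a different one, and how the core of compound 1 differs from that of compound 2 is not broken down here. In a functional assay on MDA-MB-231 cells (Homo sapiens) for cytotoxicity, read by MTT assay (on this read-out higher numbers stand for weaker inhibition and lower numbers for stronger inhibition), compound 1 gives > 10000 nM, which is a limit of the assay and not a number. In this assay compound 2 gives > 10000 nM, also a limit. In this assay compound 3 gives > 10000 nM, again a limit. The change from compound 2 to compound 3 is hydrogen in place of methoxy on an aromatic carbon and its step is a step that the two limits leave unreadable from compound 2 to compound 3, because of the limit of > 10000 nM in this assay, at which 3 of the 3 values shown sit.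

Compound 4 `COc1cc(OC)cc(-n2cc(-c3ccc(N)cc3)nn2)c1` is not yet measured in this assay. Going by the values given here, it differs from compound 1 by hydrogen in place of methoxy on an aromatic carbon, the same change as the one from compound 2 to compound 3. Compound 4 is expected to give about 15000 nM in this assay, estimated to lie between 5000 nM and 60000 nM. The expected step, a step that the limit leaves unreadable from compound 1 to compound 4, is estimated small because compound 1 gives only the limit > 10000 nM and the parallel step is a step that the two limits leave unreadable from compound 2 to compound 3, so another limit is the likeliest outcome for compound 4.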

Compound 4, half-maximal inhibitory concentration: > 10000 nM
Compound 4: a limit, no number (the forecaster's own chance of this, stated with the estimate: 80%); the middle value lies beyond the limit too.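

In this assay compound 4 gives > 10000 nM, a limit of the assay and not a number. Going by these compounds alone, no step can therefore be read between compound 1 and compound 4, because the result adds only another limit: the limit of > 10000 nM in this assay, at which 4 of the 4 values shown sit. The compounds shown leave open whether hydrogen in place of methoxy changes cytotoxicity on either core.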